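Furan regiochemistry in a tricyclic bile acid receptor series

This account rests on a few compounds, and the source may have more. Where it says the series, first, only, none or still open, it means among the compounds named here.

Measured compounds:
- compound 1 `Cc1ccccc1-n1nc(C)c2c1NC(=O)[C@H](C)S[C@@H]2c1ccc(-c2ccoc2)cc1`: 3500 nM
- compound 2 `Cc1nn(-c2ccccc2Cl)c2c1C(c1ccc(Oc3ccccc3)cc1)SC(C)C(=O)N2`: 2700 nM
- compound 3 `Cc1nn(-c2ccccc2Br)c2c1C(c1ccc(Oc3ccccc3)cc1)SC(C)C(=O)N2`: 1800 nM

In an assay on isolated protein for agonist activity at Bile acid receptor (Homo sapiens), read by AlphaScreen, with a stated time of 30 min (on this read-out lower numbers stand for an effect already at smaller amounts and higher numbers for an effect only at larger amounts of compound), compound 1 gives 3500 nM, the highest of the three numbers, but its gaps to compound 2 and to compound 3 are both within the scatter, so the three compounds stand together on this read-out. Going by the values given here, the one step between compounds that differ in a single place, a 1.5-fold lower number from compound 2 to compound 3 (0.18 log units; within the scatter), also stays within the scatter.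

Compound 4 `Cc1ccccc1-n1nc(C)c2c1NC(=O)[C@H](C)S[C@@H]2c1ccc(-c2ccco2)cc1` is not yet measured. Against compound 1 the change is furan-2-yl in place of furan-3-yl on an aromatic carbon, on an aromatic carbon of a six-membered aromatic ring of carbon only. Among the compounds with values here, no measured pair concerns the furan ring or this position, so nothing among the three values speaks directly to the change; the only step known, from compound 2 to compound 3, involves a different group at a different place and was within the scatter.

On that basis no shift beyond the scatter is expected, and the estimated step of no change at the digits printed from compound 1 to compound 4 (within the scatter) is set near zero. Compound 4 is estimated at 3500 nM in this assay, with a range from 1500 nM to 8000 nM.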

Compound 4, half-maximal effective concentration: 3600 nM
The estimate for compound 4 lay 1.0-fold (0.01 log units) below the measured number; low and high end bracket the measured number.
By their numbers in this assay, from the lowest: compounds 3, 2, 1 and 4 (each within the scatter of the next).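

In this assay, going by these compounds alone, the exchange of furan-3-yl for furan-2-yl gives a 1.0-fold higher number from compound 1 to compound 4 (0.01 log units; within the scatter) and is the first reading of a change at this place, on an aromatic carbon para to a large group. The earlier step concerned a halogen elsewhere on the molecule and said nothing about this position, whereas this pair shows that, with the same atoms joined differently and the same counts of donors and acceptors, the point of attachment of the furan does not move the number beyond the scatter on the core of compound 1. No measurement at hand accounts for the two furan isomers reading alike.

The compounds shown leave open whether a group of another kind at this place, such as a carboxylic acid, an aminomethyl group or a longer alkyl chain, would move the number beyond the scatter, or whether this position simply tolerates any ring of this size. Within the data shown here, they also give no pair that isolates the furan rings from the phenoxy group of compound 2 and compound 3, since those compounds differ from compound 1 in more than one place.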